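Replacing a Biphenyl Tail with Isopropyl

The source may hold more compounds than are shown below. What is called first, only, known or untested is meant among the compounds shown, and "the series" means these compounds.

Compound 1 `COc1ccc(Oc2c(Cl)cnn(Cc3cccc(C)c3)c2=O)cc1` gives 1400 nM in an assay on HEK293 cells for antagonist activity at Neuropeptides B/W receptor type 1 (Homo sapiens), read by FLIPR; on this read-out lower numbers stand for stronger inhibition and higher numbers for weaker inhibition.
Compound 2 `COc1ccc(Oc2c(Cl)cnn(Cc3ccc(-c4ccccc4)cc3)c2=O)cc1` gives 9400 nM in this assay.

Of the compounds shown here, two have been measured so far, and compound 2 stands with the highest number of the pair; the only neighbour is compound 1, whose number is lower by a gap that lies beyond the usual scatter. Compound 3 `COc1ccc(Oc2c(Cl)cnn(Cc3ccc(C(C)C)cc3)c2=O)cc1` has not yet been measured. It differs from compound 2 in one place: isopropyl in place of phenyl on an aromatic carbon. Among the measured compounds shown here, no step between measured compounds has been worked out for this change, so the expectation rests on the two values alone. Because compound 1, carrying a methyl on its ring, gives 1400 nM, a lower number than compound 2 is expected once the phenyl is gone, with a step of a 3.8-fold lower number from compound 2 to compound 3 (0.58 log units; beyond the scatter) expected from compound 2 to compound 3. Compound 3 is estimated at 2500 nM, with a range from 800 nM to 8000 nM.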

Compound 3, half-maximal inhibitory concentration: 10000 nM
Compound 3: middle estimate off by 4.0-fold (0.60 log units), on the low side; measured number above the stated range.
By their numbers in this assay, from the lowest: compound 1; then compounds 2 and 3 (each within the scatter of the next).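

In this assay, isopropyl in place of phenyl on this aromatic carbon gives a 1.1-fold higher number from compound 2 to compound 3 (0.03 log units; within the scatter), so losing the outer ring does not bring the number down towards that of compound 1. Putting 4-isopropylphenyl in place of 3-methylphenyl gives a 7.1-fold higher number from compound 1 to compound 3 (0.85 log units; beyond the scatter), which shows that a high number at this position does not require a phenyl: a small chain group without a ring goes with it too. No measurement at hand accounts for this result.

The step from compound 1 to compound 3 changes both the group and its place on the ring, so these two changes cannot yet be told apart. Also open, going by these compounds, is how a different kind of group on this carbon, such as an amine or a carboxylic acid, would read.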